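The source may hold more compounds than are shown below. What is called first, only, known or untested is meant among the compounds shown, and "the series" means these compounds.

Measured compounds in an assay on microsomes from intestine for inhibition of acyl-CoA:cholesterol acyltransferase (Oryctolagus cuniculus); on this read-out higher numbers stand for weaker inhibition and lower numbers for stronger inhibition:

compound 1, `CCCCCCCCOC(=O)NC(=O)Oc1c(C(C)C)cccc1C(C)C`: 250 nM
compound 2, `CCCCCCCCCCOC(=O)NC(=O)Oc1c(C(C)C)cccc1C(C)C`: 74 nM
compound 3, `CCCCCCCCSC(=O)NC(=O)Oc1c(C(C)C)cccc1C(C)C`: 160 nM

Compound 1 and compound 2 differ in one place, by ethyl in place of hydrogen on a saturated chain carbon, eight bonds along the chain from an oxygen next to a carbonyl group. In this assay that change gave a 3.4-fold lower number from compound 1 to compound 2 (0.53 log units; beyond the scatter). Compound 1 and compound 3 differ in their cores by octylsulfanyl in place of octyloxy on a carbonyl carbon; this change gave a 1.6-fold lower number from compound 1 to compound 3 (0.19 log units; within the scatter), so the two values do not separate from each other. Compound 3 stands second highest of the three numbers, and its gap to compound 2 is beyond the scatter.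

Compound 4, `CCCCCCCCCCSC(=O)NC(=O)Oc1c(C(C)C)cccc1C(C)C`, has not yet been measured. It differs from compound 3 by ethyl in place of hydrogen on a saturated chain carbon, eight bonds along the chain from a sulfur. Going by the values given here, this is the same kind of change as the one from compound 1 to compound 2, made twice, but the surroundings are not identical: in the first pair the place is eight bonds along the chain from an oxygen next to a carbonyl group, in the second it is eight bonds along the chain from a sulfur.

The step from compound 3 to compound 4 is expected to be of a similar size, estimated as a 3.4-fold lower number from compound 3 to compound 4 (0.53 log units; beyond the scatter), because the first instance gave a 3.4-fold lower number from compound 1 to compound 2 (0.53 log units; beyond the scatter). The core change in the series gave only a 1.6-fold lower number from compound 1 to compound 3 (0.19 log units; within the scatter), which supports carrying that earlier step over. On that basis compound 4 is estimated at 47 nM in this assay, expected to fall between 20 nM and 120 nM.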

Compound 4, half-maximal inhibitory concentration: 130 nM
Compound 4: middle estimate off by 2.8-fold (0.44 log units), on the low side; measured number outside the range, above it.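

In this assay, ethyl in place of hydrogen on a saturated chain carbon, eight bonds along the chain from a sulfur, gave a 1.2-fold lower number from compound 3 to compound 4 (0.09 log units; within the scatter), so these two values do not separate from each other. Going by these compounds alone, the step therefore does not carry over in size from the core with the oxygen to the core with the sulfur, and a step read on one of these cores is a poor guide to the same change on the other: the same change on two cores in this assay, a 3.4-fold lower number (0.53 log units; beyond the scatter) from compound 1 to compound 2 and a 1.2-fold lower number (0.09 log units; within the scatter) from compound 3 to compound 4, 2.7-fold (0.44 log units) apart, beyond the scatter of two such steps This rests on only two matched pairs, so it shows that the size of the step depends on the core, but it does not show why, does not establish that the change has no effect on the core with the sulfur, and says nothing about how the change would behave on any further core.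

The compounds shown leave open whether a longer chain would bring the two cores together or move them further apart. They also leave open whether the difference between the steps would persist on a chain bearing an amine or a carboxylic acid.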